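The compounds below may be only part of what the source reports. "The series", "measured", "known", "first", "only" and "open" are said of these compounds alone.

Measured compounds:
compound 1 `CCCS(=O)(=O)c1cc(C#Cc2cc(Cl)ccc2OCC(=O)O)c(C)cc1NC(C)=O` — 1.3 nM
compound 2 `CS(=O)(=O)c1cncc(C#Cc2cc(Cl)ccc2OCC(=O)O)c1` — 60 nM

Both were run in an assay on CHO cells for displacement of a labelled ligand from prostaglandin D2 receptor 2 (Homo sapiens), read by scintillation counting; on this read-out higher numbers stand for weaker inhibition and lower numbers for stronger inhibition. Compound 1 gives 1.3 nM, compound 2 gives 60 nM. Compound 2 thus holds the higher of the two numbers, its gap to compound 1 lying well beyond the scatter; the two compounds differ in several places at once, so no single structural step accounts for that gap.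

The next compound, compound 3 `O=C(O)COc1ccc(Cl)cc1C#Cc1cncc(S(=O)(=O)N2CCOCC2)c1`, has not yet been measured in this assay. It is drawn from compound 2 by one change: morpholin-4-yl in place of methyl on a sulfonyl sulfur. Among the measured compounds shown here, no pair among the measured compounds carries this same change, so there is no step in hand to anchor the expectation; compound 1 carries a different sulfonyl substituent and a further amide and cannot be read as a precedent for it.

With only the value of compound 2 to go on, the expectation for compound 3 is a step of a 1.5-fold lower number from compound 2 to compound 3 (0.18 log units; within the scatter), of a size no larger than the usual scatter. Compound 3 is estimated at 40 nM, with a range from 10 nM to 200 nM.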

Compound 3, inhibition constant: 41 nM
Compound 3: the middle estimate sits 1.0-fold (0.01 log units) below what was measured, and the stated range covers the measured number.
By their numbers in this assay, from the lowest: compound 1; then compounds 3 and 2 (each within the scatter of the next).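

In this assay, among the compounds shown here, the first step that can be read at a single place is a 1.5-fold lower number from compound 2 to compound 3 (0.17 log units; within the scatter), for morpholin-4-yl in place of methyl on a sulfonyl sulfur. This position therefore accepts a group of 6 heavy atoms carrying a six-membered non-aromatic ring and a hydrogen-bond acceptor, where methyl has 1 heavy atom, with no difference beyond the scatter, something the earlier pair, which differs in several places at once, could not show. No supporting measurement is available to explain why the two numbers stay this close.

Open, on these data alone, is whether the same holds for other groups on the sulfonyl sulfur, such as a piperidine ring, a dimethylamino group or a free primary amine. Also open, as far as these compounds go, is which of the several differences between compound 1 and compound 2 carries their gap, and whether morpholin-4-yl in place of the propyl chain would read the same way on the core of compound 1.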